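A few compounds are considered here, and "the series" means these few. Any claim that something is new, unique, unknown or untested is made for them only; others in the source may bear on it.

Measured compounds:
compound 1 `Cc1c(OCCCCOc2ccccc2C(=O)O)ccc(C(=O)CC2CCCC2)c1O`, 335 nM
compound 2 `Cc1c(OCCCCOc2ccccc2C(=O)O)ccc(C(=O)CC(C)C)c1O`, 415 nM

In an assay on HEK293 cells for positive allosteric modulation of metabotropic glutamate receptor 2 (Rattus norvegicus), read by thallium flux, with a stated time of 2.5 min (on this read-out lower numbers stand for an effect already at smaller amounts and higher numbers for an effect only at larger amounts of compound), compound 1 gives 335 nM, which is the lowest of the two numbers shown. Among the measured compounds shown here, the nearest measured neighbour is compound 2 with 415 nM; the only measured step, a 1.2-fold higher number from compound 1 to compound 2 (0.09 log units; within the scatter), is within the scatter and arises from isopropyl in place of cyclopentyl on a saturated chain carbon bound to a carbonyl carbon.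

Compound 3 `Cc1cc(OCCCCOc2ccc(C(=O)CC3CCCC3)c(O)c2C)ccc1C(=O)O` differs from compound 1 elsewhere: 4-carboxy-3-methylphenyl in place of 2-carboxyphenyl on an oxygen on a saturated carbon. For the measured compounds named here, no measured step touches this part of the shared core; the step from compound 1 to compound 2 concerns a different position and offers no guide to the direction or size of this change. The expectation for compound 3 therefore rests only on the shared core and the shared four-carbon linker, with wide uncertainty in both directions.

Compound 3 is estimated at 600 nM in this assay, with a range from 120 nM to 3000 nM. This corresponds to an expected step of a 1.8-fold higher number from compound 1 to compound 3 (0.25 log units; within the scatter), which lies within the scatter but could prove to be well beyond it.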

Compound 3, half-maximal effective concentration: 564 nM
Compound 3: middle estimate off by 1.1-fold (0.03 log units), on the high side; low and high end bracket the measured number.
By their numbers in this assay, from the lowest: compounds 1, 2 and 3 (each within the scatter of the next).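

In this assay, 4-carboxy-3-methylphenyl in place of 2-carboxyphenyl on an oxygen on a saturated carbon gives a 1.7-fold higher number from compound 1 to compound 3 (0.23 log units; within the scatter), so this part of the molecule, which the earlier pair left untouched, accepts this exchange of one carboxy-bearing ring for another without a step beyond the scatter. With the shared core, the four-carbon linker and the cyclopentyl group held constant, the 2-carboxyphenyl group is thus not the only ring on this oxygen that gives a number in this range. The data offer no measured basis for explaining why these two groups read alike.

The single step joins two differences, the place of the carboxy group and the added methyl, so the compounds shown leave open what each contributes alone, which plain 4-carboxyphenyl could help to separate. Also open, as far as these compounds go, are whether a tetrazole or an amide in place of the carboxylic acid on this ring would stay in this range, and whether the isopropyl group of compound 2 would read the same alongside 4-carboxy-3-methylphenyl.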